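The source may hold more compounds than are shown below. What is called first, only, known or untested is meant among the compounds shown, and "the series" means these compounds.

In a functional assay on the whole organism with Rattus norvegicus as the target, at a dose of 100 mg/kg (on this read-out higher numbers stand for more inhibition at the one dose given (going by the name of the read-out) and lower numbers for less inhibition), compound 1 `CC/N=C(/NC#N)NCCCCn1nc(-c2ccccc2)ccc1=O` gives 58.8%, the higher of the two numbers recorded. Compound 2 `CC/N=C(/NC#N)NCCCCn1nc(-c2ccccc2)c(C)cc1=O` gives 38.8%. Putting a methyl in place of hydrogen on an aromatic carbon produced a number 20 percentage points lower from compound 1 to compound 2 (beyond the scatter). Compound 3 `CC/N=C(\S)NCCCCn1nc(-c2ccccc2)ccc1=O` differs from compound 1 at another place: a group of 5 heavy atoms (3 carbon, 1 nitrogen, 1 sulfur; no ring) in place of a group of 7 heavy atoms (4 carbon, 3 nitrogen; no ring), on an amine nitrogen. Going by the values given here, the only measured step concerns a methyl on an aromatic carbon and says nothing about this exchange on the amine nitrogen, so no direction can be drawn from it. Compound 3 is therefore expected to give about 50%, within a range from 25% to 75%, an expected step of a number 8.8 percentage points lower from compound 1 to compound 3 (within the scatter) that is not expected to exceed the scatter.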

Compound 3, a percentage reported as inhibition, in the whole organism at one dose (the size of the read-out at that dose, not a potency): 67.7%
Compound 3: middle estimate off by 17.7 percentage points, on the low side, within the range that was stated.
By their numbers in this assay, from the lowest: compound 2; then compounds 1 and 3 (each within the scatter of the next).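

On the amine nitrogen, the group of 5 heavy atoms (3 carbon, 1 nitrogen, 1 sulfur; no ring) can take the place of the group of 7 heavy atoms (4 carbon, 3 nitrogen; no ring) in this assay, with a number 8.9 percentage points higher from compound 1 to compound 3 (within the scatter). This position therefore accepts this exchange at the one dose given, while the earlier step spoke only of a methyl on an aromatic carbon. Nothing available here explains the result.

As far as these compounds go, whether a urea or a simple amine on this nitrogen would keep the read-out in this range remains open. So does the outcome of the aromatic methyl when it is combined with the group of 5 heavy atoms.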